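The source may hold more compounds than are shown below. What is called first, only, known or untested is meant among the compounds shown, and "the series" means these compounds.

Compound 3 `COC(=O)c1ccc(Cc2nn(C[C@H]3CCCN3C)c(=O)c3ccccc23)cc1` carries a methoxycarbonyl group on one of its aromatic rings. In an assay for binding affinity to Alpha-1B adrenergic receptor (Homo sapiens) (a lower number here means a stronger inhibitor, a higher number a weaker inhibitor), compound 3 gives > 1990 nM, which is a limit of the assay rather than a measured number. Compound 4 `COc1ccc(Cc2nn(C[C@H]3CCCN3C)c(=O)c3ccccc23)cc1` has not been measured; it differs from compound 3 by methoxy in place of methoxycarbonyl on an aromatic carbon. Among the measured compounds, compound 1 `CN1CCC[C@@H]1Cn1nc(Cc2cccc(Cl)c2)c2ccccc2c1=O` gives 631 nM in this assay. Compound 2 `CN1CCC[C@@H]1Cn1nc(CC2CCCCC2)c2ccccc2c1=O` gives > 1990 nM in this assay, again a limit of the assay. Among the measured compounds shown here, the step of an at least 3.1-fold higher number from compound 1 to compound 2 (0.49 log units; beyond the scatter) concerns a different part of the molecule, so no measured step bears directly on the change from compound 3 to compound 4. Most of what is known sits at the limit of > 1990 nM in this assay, at which 2 of the 3 values shown sit, so the series gives little to build on. Compound 4 is expected to land at 1500 nM, within 400 nM to 6000 nM. The expected step is an at least 1.3-fold lower number from compound 3 to compound 4 (0.12 log units; that floor lies within the scatter), a cautious guess toward the range of compound 1 without any measured step to support it.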

Compound 4, inhibition constant: 158 nM
Beside the measured number, compound 4's estimate is 9.5-fold (0.98 log units) above it, and the stated range ends above it.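

On an aromatic carbon para to a large group, in this assay, methoxy in place of methoxycarbonyl brings an at least 12-fold lower number from compound 3 to compound 4 (1.10 log units; beyond the scatter) and shows that the group at this position can decide the result; compound 3 stands at a limit of the assay, so the true step could be larger. The comparisons on the saturated chain carbon give an at least 12-fold lower number from compound 2 to compound 4 (1.10 log units; beyond the scatter) and a 4.0-fold lower number from compound 1 to compound 4 (0.60 log units; beyond the scatter) and point the same way, with the first of these also resting on a limit. Compound 4 is therefore the strongest of the four compounds, while part of the series remains at the limit: the limit of > 1990 nM in this assay, at which 2 of the 4 values shown sit.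

Only methoxy and methoxycarbonyl are shown at this position, so one comparison cannot separate what each group contributes. A hydroxyl, an ethoxy or a dimethylamino group here would show how narrowly the result depends on methoxy.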